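The source may hold more compounds than are shown below. What is called first, only, known or untested is meant among the compounds shown, and "the series" means these compounds.

Compound 1, `O=C(NCc1cc(Cl)ccc1-n1cnnn1)[C@@H]1CC=NN1C(=O)[C@H](O)c1ccccc1`, gives 840 nM in a functional assay on a cell-free system (plasma, Homo sapiens), with a stated time of 3 min; on this read-out lower numbers stand for stronger inhibition and higher numbers for weaker inhibition.
Compound 2, `CC(C)(C)C[C@@H](O)C(=O)N1N=CC[C@H]1C(=O)NCc1cc(Cl)ccc1-n1cnnn1`, gives 590 nM in this assay.
Compound 3, `O=C(NCc1cc(Cl)ccc1-n1cnnn1)[C@@H]1CCON1C(=O)[C@H](O)c1ccccc1`, gives 1500 nM in this assay.

Compound 1 and compound 2 share one core and differ only in one group: neopentyl in place of phenyl on a saturated chain carbon bound to a carbonyl carbon and an oxygen on a saturated carbon. That change gave a 1.4-fold lower number from compound 1 to compound 2 (0.15 log units; within the scatter), so the two numbers sit close together and no order between them can be claimed.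

Compound 3 carries a different core from compound 1; the difference between the two cores is not broken down here. For the measured compounds named here, of the three measured numbers, the one for compound 3 is the highest, yet its gap to compound 1 stays within the scatter, while its gap to compound 2 lies beyond it.

Compound 4, `CC(C)(C)C[C@@H](O)C(=O)N1OCC[C@H]1C(=O)NCc1cc(Cl)ccc1-n1cnnn1`, has not yet been measured in this assay. It stands to compound 3 as compound 2 stands to compound 1: neopentyl in place of phenyl on a saturated chain carbon bound to a carbonyl carbon and an oxygen on a saturated carbon, at the same place, word for word. Going by the values given here, the only guide to what this change does is the step from compound 1 to compound 2, which stayed within the scatter. On that single precedent, the step from compound 3 to compound 4 in this assay is expected to be of similar size, that is a 1.4-fold lower number from compound 3 to compound 4 (0.13 log units; within the scatter), again within the scatter, because compound 2 gave 590 nM against compound 1. For compound 4 the estimate is therefore 1100 nM, with a likely range from 450 nM to 2700 nM, which only the measurement can settle.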

Compound 4, half-maximal inhibitory concentration: 1100 nM
For compound 4 middle estimate and measured number coincide at the digits printed; measured number inside the range.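

On the core of compound 3, putting neopentyl in place of phenyl gave a 1.4-fold lower number from compound 3 to compound 4 (0.13 log units; within the scatter) in this assay. The exchange therefore reads the same on both cores, with each step small and the two steps in close agreement: the same change on two cores in this assay, a 1.4-fold lower number (0.15 log units; within the scatter) from compound 1 to compound 2 and a 1.4-fold lower number (0.13 log units; within the scatter) from compound 3 to compound 4, 1.0-fold (0.02 log units) apart, within the scatter of two such steps. This supports a modest conclusion: in these two matched pairs, phenyl and neopentyl cannot be told apart at this place, even though one is an aromatic ring and the other an open, ringless group, but two steps that each lie within the scatter show no real effect that has been carried from one core to the other, and two cores say nothing firm about a third.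

The compounds shown leave open what happens with other groups on the saturated chain carbon bound to a carbonyl carbon and an oxygen on a saturated carbon, such as an amine, a carboxylic acid or a longer chain, any of which might give a step large enough to rise clear of the scatter. Only such a step could test whether a real change in inhibition carries over between these cores, and whether the two cores then respond alike.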